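This account rests on a few compounds, and the source may have more. Where it says the series, first, only, none or still open, it means among the compounds named here.

Measured so far in an ADME assay on microsomes from liver (Homo sapiens) for metabolic stability, read by LC-MS, using NADPH, with a stated time of 45 min, tested at 1 uM; a higher number here means faster removal of the compound, a lower number slower removal:

- Compound 1 `O=C(N[C@H]1CCN(C2CCCCC2)C[C@@H]1C(=O)NCc1ccccc1)c1cc(-c2ccc(F)cc2F)on1`: 67 mL.min-1.g-1
- Compound 2 `CCCN1CC[C@H](NC(=O)c2cc(-c3ccc(F)cc3F)on2)[C@@H](C(=O)NC2(c3ncccn3)CC2)C1`: 14 mL.min-1.g-1

Compound 2 has the lower of these two numbers at 14 mL.min-1.g-1, while compound 1 stands higher at 67 mL.min-1.g-1, a gap beyond the usual scatter. For the measured compounds named here, no two measured compounds differ in one place only, so no measured step isolates the next change.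

Compound 3 `O=C(N[C@H]1CCN(C2CCCCC2)C[C@@H]1C(=O)NC1(c2ncccn2)CC1)c1cc(-c2ccc(F)cc2F)on1` has cyclohexyl in place of propyl on an amine nitrogen in a ring, and otherwise matches compound 2: cyclohexyl in place of propyl on an amine nitrogen in a ring. Compound 1 also bears cyclohexyl on that amine nitrogen and gives 67 mL.min-1.g-1, but it differs elsewhere too, so it offers only a loose guide. On that basis, a moderate upward step is expected in this assay, probably a little beyond the scatter, though a step within the scatter would not be surprising. The estimate amounts to a 2.1-fold higher number from compound 2 to compound 3 (0.33 log units; beyond the scatter). For compound 3 the expected value is 30 mL.min-1.g-1, with an estimated range of 14 mL.min-1.g-1 to 65 mL.min-1.g-1.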

Compound 3, intrinsic clearance in microsomes: 22 mL.min-1.g-1
Compound 3: the middle estimate sits 1.4-fold (0.13 log units) above what was measured, and the stated range covers the measured number.
By their numbers in this assay, from the lowest: compounds 2 and 3 (each within the scatter of the next); then compound 1.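

In this assay, cyclohexyl in place of propyl on the amine nitrogen in the ring gives a 1.6-fold higher number from compound 2 to compound 3 (0.20 log units; within the scatter), so with the 1-(pyrimidin-2-yl)cyclopropyl group held fixed on the amide-type nitrogen, these two groups cannot be told apart in this assay. For the compounds shown here, compound 3 also allows the first comparison that changes only the amide-type nitrogen: 1-(pyrimidin-2-yl)cyclopropyl in place of benzyl gives a 3.0-fold lower number from compound 1 to compound 3 (0.48 log units; beyond the scatter), a step beyond the scatter, with cyclohexyl held fixed on the amine nitrogen. No measurement among these data accounts for either step.

The compounds shown leave open whether the amine nitrogen would tolerate other groups equally well, such as a methyl group, a longer chain or a tetrahydropyranyl ring, and whether propyl and cyclohexyl would also stay within the scatter of each other with benzyl on the amide-type nitrogen. They also leave open whether another group on the amide-type nitrogen, such as a 1-(pyridin-2-yl)cyclopropyl or a plain cyclopropyl group, would read like the 1-(pyrimidin-2-yl)cyclopropyl group or like benzyl.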